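Epimer of compound 2 in the cell growth assay

This account rests on a few compounds, and the source may have more. Where it says the series, first, only, none or still open, it means among the compounds named here.

Three peroxide-bearing analogues have numbers in a functional assay on UACC-257 cells (Homo sapiens) for inhibition (a lower number here means a stronger inhibitor of growth, a higher number a weaker inhibitor of growth), so far. Compound 1 `COC(=O)[C@H](C)[C@H]1CC[C@@](C)(CCC2=C(C)CCCC2(C)C)OO1` sits at the limit of the assay, > 25000 nM, which is a bound and not a measured number. Compound 2 `C=C1CCC[C@H]2[C@](C)(CC[C@]3(C)CC[C@H]([C@@H](C)C(=O)O)OO3)[C@@H](C)CC[C@]12C` gives 3680 nM. Compound 3 `C=C1CCCC(C)(C)C1CC[C@]1(C)CC[C@H]([C@@H](C)C(=O)OC)OO1` gives 16300 nM. Of the two measured numbers, compound 2 holds the lower one, and its gap to compound 3 lies beyond the usual scatter; the value of compound 1 is a limit only (the limit of > 25000 nM in this assay, at which 1 of the 3 values shown sits).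

Compound 4 `C=C1CCC[C@H]2[C@](C)(CC[C@]3(C)CC[C@@H]([C@@H](C)C(=O)O)OO3)[C@@H](C)CC[C@]12C` has not yet been measured. Relative to compound 2 the change is the two compounds have the same atoms and bonds and differ only in configuration as drawn: 1 of 7 stereo elements differ; a stereocentre at a saturated ring carbon is drawn R in compound 2 and S in compound 4. Within the data shown here, no pair of measured compounds differs in one place, so no measured step guides the size of this change. A configurational swap of this kind may move the number either way; a moderate loss is expected, though a step within the scatter cannot be ruled out. Compound 4 is therefore estimated at 7000 nM, with a range from 2000 nM to 25000 nM, which corresponds to an expected step of a 1.9-fold higher number from compound 2 to compound 4 (0.28 log units; within the scatter).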

Compound 4, concentration for 50% growth inhibition: > 5000 nM
Compound 4 ended at the assay's limit; the forecaster's own chance of this, stated with the estimate: 15%; the middle value does not contradict the limit.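

This pair gives the series its first step in one place, at a stereocentre at a saturated ring carbon: in this assay the swap from R to S gives an at least 1.3-fold higher number from compound 2 to compound 4 (0.13 log units; that floor lies within the scatter), so the data fix only a floor and do not show a shift beyond the scatter. Compound 4 gives > 5000 nM, which is a limit of the assay and not a number. Any real gap between these two numbers could be assigned to this one stereocentre alone, because of how the pair is built: the fact that compounds 2 and 4 differ only in the configuration as drawn.

On these data alone, how far the true number of compound 4 lies from that of compound 2 remains open. Also open, as far as these compounds go, are whether the same swap has a comparable effect on the methyl ester of compound 3, and whether a primary amide in place of the carboxylic acid of compound 2 retains growth inhibition.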